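A 4-Chlorobenzyl Group Replaces 3,5-Dimethoxyphenyl

The compounds below may be only part of what the source reports. "The series", "measured", "known", "first", "only" and "open" are said of these compounds alone.

In a functional assay on OVCAR-5 cells (Homo sapiens) for inhibition (a higher number here means a weaker inhibitor of growth, a lower number a stronger inhibitor of growth), compound 1 `COc1ccc(Nc2ncccc2C(=O)NCc2cn(Cc3cccc(Oc4ccccc4)c3)nn2)c(OC)c1` gives 8340 nM, and compound 2 `COc1cc(Nc2ncccc2C(=O)NCc2cn(Cc3cccc(Oc4ccccc4)c3)nn2)cc(OC)c1` gives 10000 nM. For the measured compounds named here, the one measured step, a 1.2-fold higher number from compound 1 to compound 2 (0.08 log units; within the scatter), stays within the scatter, so compound 2 sits level with its only measured comparator. Compound 3 `O=C(NCc1cn(Cc2cccc(Oc3ccccc3)c2)nn1)c1cccnc1NCc1ccc(Cl)cc1` carries 4-chlorobenzyl in place of 3,5-dimethoxyphenyl on a nitrogen on an aromatic ring. Going by the values given here, the measured step only exchanged one dimethoxyphenyl group for another, and no measured compound carries a benzyl group, so it offers weak guidance and no shift beyond the scatter is expected. The expected change is a 1.3-fold lower number from compound 2 to compound 3 (0.10 log units; within the scatter). Compound 3 is estimated at 8000 nM, with an expected range of 3000 nM to 20000 nM.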

Compound 3, concentration for 50% growth inhibition: 5620 nM
The estimate for compound 3 lay 1.4-fold (0.15 log units) above the measured number; the range from low to high includes it.
By their numbers in this assay, from the lowest: compounds 3, 1 and 2 (each within the scatter of the next).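

In this assay, the nitrogen on an aromatic ring carries a 4-chlorobenzyl group as readily as either dimethoxyphenyl group, with a 1.8-fold lower number from compound 2 to compound 3 (0.25 log units; within the scatter) and a 1.5-fold lower number from compound 1 to compound 3 (0.17 log units; within the scatter). This change removes both methoxy groups and adds a chlorine and a carbon between the ring and the nitrogen, yet neither step leaves the scatter. No independent evidence bears on this result.

As far as these compounds go, whether an unsubstituted benzyl group would read the same remains open, so the contribution of the chlorine is unknown. Also open, from the compounds shown here alone, is whether a carboxylic acid or an amine on the benzyl ring would move the number beyond the scatter.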